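Trading the octyl tail of compound 2 for an aryl group

The source may hold more compounds than are shown below. What is called first, only, known or untested is meant among the compounds shown, and "the series" means these compounds.

In a functional assay on cells (T-cell line, Homo sapiens) for inhibition (a lower number here means a stronger inhibitor, a higher number a weaker inhibitor), compound 1 `CCCCN1CCC(COC(c2ccccc2)c2ccccc2)CC1` gives 14000 nM and compound 2 `CCCCCCCCCN1CCC(COC(c2ccccc2)c2ccccc2)CC1` gives 700 nM as the lower of the two numbers. Among the measured compounds shown here, the one measured step is a 20-fold lower number from compound 1 to compound 2 (1.30 log units; beyond the scatter) and comes with a longer chain. Compound 3 `COc1ccc(/C=C/CN2CCC(COC(c3ccccc3)c3ccccc3)CC2)cc1` differs from compound 2 as follows: 2-(4-methoxyphenyl)ethenyl in place of octyl on a saturated chain carbon bound to an amine nitrogen in a ring and the shared core stays. That step tests no aromatic group, so it gives only weak guidance. The entering group is close to octyl in size, so the estimated change is a 1.4-fold higher number from compound 2 to compound 3 (0.15 log units; within the scatter) in this assay and no step beyond the scatter is expected. Compound 3 is estimated at 1000 nM with 250 nM to 5000 nM as its expected range.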

Compound 3, half-maximal inhibitory concentration: 4300 nM
For compound 3 the middle estimate is 4.3-fold (0.63 log units) below the measured one; the measured number falls inside the stated range.
By their numbers in this assay, from the lowest: compound 2; then compound 3; then compound 1.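

At the saturated chain carbon bound to an amine nitrogen in a ring, an aromatic group now has a reading in this assay. 2-(4-methoxyphenyl)ethenyl in place of octyl brings a 6.1-fold higher number from compound 2 to compound 3 (0.79 log units; beyond the scatter), while the same group in place of propyl brings a 3.3-fold lower number from compound 1 to compound 3 (0.51 log units; beyond the scatter), so it keeps only part of the gain seen with the longer chain. Nothing available bears on the cause of these steps. Open remain a saturated 3-phenylpropyl group, which has neither the methoxy nor the double bond, and a chain longer than octyl.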